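A few compounds are considered here, and "the series" means these few. Any claim that something is new, unique, unknown or untested is made for them only; others in the source may bear on it.

Measured so far:
compound 1 `Cc1ccc(S(=O)(=O)N2CCN(C)CC2)cc1C#Cc1cc(Cl)ccc1OCC(=O)O`: 21 nM
compound 2 `CN(C)C(=O)c1ccc(C#Cc2cc(Cl)ccc2OCC(=O)O)cc1`: 55 nM
compound 3 `O=C(O)COc1ccc(Cl)cc1C#Cc1ccccc1`: 108 nM

In an assay on CHO cells for displacement of a labelled ligand from prostaglandin D2 receptor 2 (Homo sapiens), read by scintillation counting (a lower number here means a stronger inhibitor, a higher number a weaker inhibitor), compound 1 shows the lowest of the three numbers, below both compound 2 and compound 3. Compound 4 `CCN(CC)S(=O)(=O)c1ccc(C)c(C#Cc2cc(Cl)ccc2OCC(=O)O)c1` differs from compound 1 in one place: diethylamino in place of 4-methylpiperazin-1-yl on a sulfonyl sulfur. Among the measured compounds shown here, no measured pair varies exactly this spot. For the measured compounds named here, the only measured step on the far aromatic ring, a 2.0-fold higher number from compound 2 to compound 3 (0.29 log units; within the scatter), shows that changing a substituent there moves the number little. Both groups exchanged here carry no net charge, and the sulfonyl stays. The step expected for compound 4 is therefore small, a 1.2-fold higher number from compound 1 to compound 4 (0.08 log units; within the scatter), not clearly beyond the scatter. Compound 4 is estimated at 25 nM, with a range from 10 nM to 65 nM.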

Compound 4, inhibition constant: 3.4 nM
The estimate for compound 4 lay 7.4-fold (0.87 log units) above the measured number, and the stated range ends above it.
By their numbers in this assay, from the lowest: compound 4; then compound 1; then compounds 2 and 3 (each within the scatter of the next).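

In this assay the group on the sulfonyl sulfur clearly counts: diethylamino in place of 4-methylpiperazin-1-yl gives a 6.2-fold lower number from compound 1 to compound 4 (0.79 log units; beyond the scatter) and this step lies beyond the scatter. At this place, then, the number does not depend on keeping the six-membered ring or its second nitrogen. Nothing available explains the change.

Still open, going by these compounds, is whether losing the ring or losing the nitrogen matters more, which piperidin-1-yl on the same sulfur could separate. Also open, on these data alone, is how the shorter dimethylamino or the longer dipropylamino would compare.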